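The source may hold more compounds than are shown below. What is called first, only, known or untested is meant among the compounds shown, and "the series" means these compounds.

In an ADME assay on cells (Hepatocyte, Rattus norvegicus) for metabolic stability (a higher number here means faster removal of the compound, a lower number slower removal), compound 1 `Cc1ccc2[nH]c(C(=O)N[C@H]3CN(S(=O)(=O)c4ccccc4)C[C@@H]3C(=O)N[C@H]3CCCNC3)cc2c1` gives 7 uL/min. Compound 2 `O=C(N[C@H]1CN(S(=O)(=O)c2ccccc2)C[C@@H]1C(=O)N[C@H]1CCCNC1)c1cn(C2CC2)cn1` gives < 1 uL/min, which is a limit of this assay rather than a number. The step of an at least 7.0-fold lower number from compound 1 to compound 2 (0.84 log units; beyond the scatter) is the only measured one here, and compound 2 sits at the limit of < 1 uL/min in this assay, at which 1 of the 2 values shown sits. Compound 3 `O=C(N[C@H]1CN(S(=O)(=O)c2ccccc2)C[C@@H]1C(=O)N[C@H]1CCCNC1)c1cc(-c2ccccc2)on1` carries a change at the same carbonyl carbon: 5-phenyl-1,2-oxazol-3-yl in place of 1-cyclopropyl-1H-imidazol-4-yl on a carbonyl carbon. Within the data shown here, no measured step covers this particular swap, so the expectation rests on the limit alone. Compound 3 is expected to give about 3 uL/min, within 1 uL/min to 10 uL/min. The estimated step of an at least 3.0-fold higher number from compound 2 to compound 3 (0.47 log units; beyond the scatter) is therefore a small rise, possibly within the scatter.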

Compound 3, intrinsic clearance in a liver preparation (reported as CLH), per the amount of preparation that the assay uses: 6.8 uL/min
For compound 3 the middle estimate is 2.3-fold (0.36 log units) below the measured one, and the stated range covers the measured number.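

In this assay, placing 5-phenyl-1,2-oxazol-3-yl instead of 1-cyclopropyl-1H-imidazol-4-yl on the carbonyl carbon gives an at least 6.8-fold higher number from compound 2 to compound 3 (0.83 log units; beyond the scatter), so the low number of compound 2 does not hold for every five-membered aromatic ring with 2 hetero atoms here. The value for compound 2 is a limit and not a number, so the true step could be larger: the limit of < 1 uL/min in this assay, at which 1 of the 3 values shown sits. Two quite different groups also give matching results, with a 1.0-fold lower number from compound 1 to compound 3 (0.01 log units; within the scatter).

The compounds shown do not separate the contribution of the phenyl ring from that of the 1,2-oxazole ring. On these data alone, how a plain phenyl ring or an alkyl chain would behave on this carbonyl carbon stays open.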